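The compounds below may be only part of what the source reports. "The series", "measured", "known", "first", "only" and "open" are said of these compounds alone.

Compound 1 `Cc1nc(S(C)(=O)=O)ccc1Oc1ncnc(OC2CCN(C(=O)O[C@H](C)CF)CC2)c1F` and compound 2 `Cc1nc(S(C)(=O)=O)ccc1Oc1ncnc(OC2CCN(C(=O)SC(C)(C)C)CC2)c1F` share one core and differ only at the carbonyl carbon on the piperidine nitrogen. Within the data shown here, in a functional assay on isolated protein for inhibition of Glucose-dependent insulinotropic receptor (Rattus norvegicus), read by HTRF and cAMP accumulation (a lower number here means a smaller maximal response, a higher number a larger maximal response), compound 1 gives 79% and compound 2 gives 76%, the lower of the two numbers so far, though a number 3 percentage points lower from compound 1 to compound 2 (within the scatter). Compound 3 `Cc1nc(S(C)(=O)=O)ccc1Oc1ncnc(OC2CCN(C(=O)c3noc(C(C)C)n3)CC2)c1F` follows, with 5-isopropyl-1,2,4-oxadiazol-3-yl in place of (tert-butyl)sulfanyl on a carbonyl carbon. Among the measured compounds shown here, the single measured step at this carbonyl carbon exchanged one chain for another of equal size and stayed within the scatter; an aromatic ring entering here has no precedent, so the step of a number 2 percentage points lower from compound 2 to compound 3 (within the scatter) is expected to stay modest. Compound 3 is estimated at 74%, ranging from 60% to 88%.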

Compound 3, largest response reached (reported as efficacy), in percent of the reference or control that the assay uses: 81%
Estimate against measurement, compound 3: 7 percentage points below; the measured number falls inside the stated range.
By their numbers in this assay, from the lowest: compounds 2, 1 and 3 (each within the scatter of the next).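

On the carbonyl carbon whose other neighbour is the amide-type nitrogen in a ring, an aromatic ring now has a reading in this assay: 5-isopropyl-1,2,4-oxadiazol-3-yl in place of (tert-butyl)sulfanyl gives a number 5 percentage points higher from compound 2 to compound 3 (within the scatter) and, set against the chain of compound 1, a number 2 percentage points higher from compound 1 to compound 3 (within the scatter) so the larger ring and both open chains cannot be told apart here. No measurement bears on why the response stays level at this position. Going by these compounds, whether a primary amine, a carboxylic acid or a longer chain on this carbonyl carbon would move the maximal response beyond the scatter remains open.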